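Replacing a methoxyphenyl with a chlorophenyl on the ring nitrogen

The source may report more compounds than this note shows. Statements on the series, on what has been measured and on what is new or still open speak of the compounds shown alone.

Compound 3 `COc1ccc(N2CCN(Cn3nc(-c4ccc5c(c4)OCCO5)oc3=S)CC2)cc1` gives 18900 nM in a functional assay on BGC-823 cells (Homo sapiens) for antiproliferative activity, read by MTT assay, with a stated time of 48 h (a higher number here means a weaker inhibitor, a lower number a stronger inhibitor), the lowest of the two plain numbers shown. Compound 1 `Cc1ccc(N2CCN(Cn3nc(-c4ccc5c(c4)OCCO5)oc3=S)CC2)c(C)c1` gives 28300 nM; the difference a 1.5-fold lower number from compound 1 to compound 3 (0.18 log units; within the scatter) is within the scatter. For compound 2 `S=c1oc(-c2ccc3c(c2)OCCO3)nn1CN1CCN(c2ccc(Cl)cc2)CC1` the assay reports only a limit, > 50000 nM. The step of an at least 2.6-fold lower number from compound 2 to compound 3 (0.42 log units; beyond the scatter) is beyond the scatter, and an at least 1.7-fold higher number from compound 1 to compound 2 (0.24 log units; that floor lies within the scatter) reaches that limit. Compound 4 `S=c1oc(-c2ccc3c(c2)OCCO3)nn1CN1CCN(c2ccccc2Cl)CC1` differs from compound 3 by 2-chlorophenyl in place of 4-methoxyphenyl on an amine nitrogen in a ring. A chlorine on the phenyl gave the weakest result in compound 2, though at a different position, so a higher number is expected: a 1.9-fold higher number from compound 3 to compound 4 (0.27 log units; within the scatter). Compound 4 is estimated at 35000 nM, between 15000 nM and 60000 nM.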

Compound 4, half-maximal inhibitory concentration: > 50000 nM
Compound 4 was reported as a limit; the forecaster's own chance of this, stated with the estimate: 40%; middle value at least 1.4-fold (0.15 log units) from the limit.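

Compound 4 is also reported only as a limit, so a chlorine on the phenyl reaches the limit at both positions shown, and the step of an at least 2.6-fold higher number from compound 3 to compound 4 (0.42 log units; beyond the scatter) is a second clear loss against the 4-methoxyphenyl. The step of an at least 1.7-fold higher number from compound 1 to compound 4 (0.24 log units; that floor lies within the scatter) says less, with a floor that does not clear the scatter. The two chlorophenyl compounds cannot be ordered, because both are limits: the limit of > 50000 nM in this assay, at which 2 of the 4 values shown sit.

Still open, going by these compounds, is how far beyond the limit either chlorophenyl compound lies. Also open, on these data alone, is how an amine or a hydroxyl on the phenyl would read here.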